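This account rests on a few compounds, and the source may have more. Where it says the series, first, only, none or still open, it means among the compounds named here.

Compound 1, `COc1cc(/C=N/NC(=O)c2ccncc2)cc(OC)c1O`, is the starting point. In a physicochemical assay on cells (Homo sapiens), with a stated time of 18 h, tested at 1 uM (a lower number here means a stronger effect, a higher number a weaker effect of the compound at the concentration tested), compound 1 gives 48%. Compound 2, `COc1cc(/C=N/NC(=O)OCc2ccccc2)cc(OC)c1O`, differs from compound 1 in one place: benzyloxy in place of pyridin-4-yl on a carbonyl carbon. In this assay compound 2 gives 38%, and the step is a number 10 percentage points lower from compound 1 to compound 2 (within the scatter). Compound 3, `COc1cc(/C=N/NC(=O)c2ccncc2)cc(O)c1O`, differs from compound 1 in another place: hydrogen in place of methyl on an oxygen on an aromatic ring. In this assay compound 3 gives 59%, so the step is a number 11 percentage points higher from compound 1 to compound 3 (beyond the scatter).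

Compound 4, `COc1cc(/C=N/NC(=O)OCc2ccccc2)cc(O)c1O`, has not yet been measured in this assay. It differs from compound 2 in the same way: hydrogen in place of methyl on an oxygen on an aromatic ring. The surroundings of the place are the same in both pairs, so this is the same change, made on the core of compound 2 rather than that of compound 1. Because compound 3 moved away from compound 1 by a number 11 percentage points higher from compound 1 to compound 3 (beyond the scatter), the expected step from compound 2 to compound 4 is estimated as a number 11 percentage points higher from compound 2 to compound 4 (beyond the scatter). On this basis compound 4 is expected to give about 49%, likely between 38% and 60%.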

Compound 4, a percentage reported as activity, at one concentration (the size of the read-out at that concentration, not a potency): 17%
Compound 4: middle estimate off by 32 percentage points, on the high side, outside the stated range (below it).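

Moving from methoxy to hydroxy did not carry over from one core to the other: in this assay the change gives a number 11 percentage points higher from compound 1 to compound 3 (beyond the scatter) but also a number 21 percentage points lower from compound 2 to compound 4 (beyond the scatter) and so runs in opposite directions. The two pairs differ only in the group on the carbonyl carbon, pyridin-4-yl in one and benzyloxy in the other, so the outcome of this change depends on that core here, although two pairs cannot show how general this is. Nothing measured here explains the reversal.

On these data alone, it remains open how the same change behaves with other groups on the carbonyl carbon, such as an amine or a longer alkyl chain. Whether ethoxy in place of methoxy would follow either pair is also unknown.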